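A Sulfonamide in Place of the Benzamide: Compound 4 Foreseen

This account rests on a few compounds, and the source may have more. Where it says the series, first, only, none or still open, it means among the compounds named here.

Measured compounds in an assay on isolated protein for inhibition of Rho-associated protein kinase 2 (Homo sapiens), read by scintillation counting, radiometric assay and 33P incorporation, with a stated time of 40 min, in the presence of a further agent that is not named here; on this read-out lower numbers stand for stronger inhibition and higher numbers for weaker inhibition:
- compound 1 `CCc1ccc(C(=O)Nc2cccc(NC(=O)COc3ccc4c(=O)ccoc4c3)c2)cc1` gives 24 nM
- compound 2 `O=C(COc1ccc2c(=O)ccoc2c1)Nc1cccc(NC(=O)c2ccc(F)cc2)c1` gives 54 nM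
- compound 3 `CCOc1ccc(C(=O)Nc2cccc(NC(=O)COc3ccc4c(=O)ccoc4c3)c2)cc1` gives 9 nM

Compound 3 stands lowest of the three numbers in this assay. The steps among the measured compounds all change one substituent on an aromatic carbon: a 2.3-fold higher number from compound 1 to compound 2 (0.35 log units; beyond the scatter), a 2.7-fold lower number from compound 1 to compound 3 (0.43 log units; beyond the scatter) and a 6.0-fold lower number from compound 2 to compound 3 (0.78 log units; beyond the scatter). Compound 4 `Cn1ccc(S(=O)(=O)Nc2cccc(NC(=O)COc3ccc4c(=O)ccoc4c3)c2)n1` departs from compound 3 in a different way: a group of 9 heavy atoms (4 carbon, 2 nitrogen, 2 oxygen, 1 sulfur; one five-membered aromatic ring with 2 hetero atoms) in place of a group of 11 heavy atoms (9 carbon, 2 oxygen; one six-membered aromatic ring of carbon only), on a nitrogen on an aromatic ring. None of the three measured steps touches this part of the molecule, so they give no direct guide to the size of the change; they only show that the benzamide series as a whole stays within a narrow band. The step from compound 3 to compound 4 is therefore expected to be large and upward, a 33-fold higher number from compound 3 to compound 4 (1.52 log units; beyond the scatter), with wide uncertainty. Compound 4 is estimated at 300 nM in this assay, within a range from 60 nM to 1500 nM.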

Compound 4, half-maximal inhibitory concentration: 1350 nM
For compound 4 the middle estimate is 4.5-fold (0.65 log units) below the measured one, and the stated range covers the measured number.
By their numbers in this assay, from the lowest: compound 3; then compound 1; then compound 2; then compound 4.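

In this assay, replacing the aroyl group on the aromatic nitrogen proved far more costly than any substituent change on the benzamide ring, with a 150-fold higher number from compound 3 to compound 4 (2.18 log units; beyond the scatter) and a 56-fold higher number from compound 1 to compound 4 (1.75 log units; beyond the scatter) as the new steps. Even the highest-numbered benzamide lost ground to the change, with a 25-fold higher number from compound 2 to compound 4 (1.40 log units; beyond the scatter), so the position responds much more strongly to this replacement than the earlier ethyl, fluoro and ethoxy exchanges had shown. No measurement here offers an explanation for the loss.

The change altered the carbonyl link and the ring together, so the compounds shown cannot assign the loss to either one. From the compounds shown here alone, a phenylsulfonyl group bearing ethoxy, or a carbonyl carrying the same five-membered ring, would separate the two, and whether other sulfonyl-linked rings behave like compound 4 remains open.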